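Permeability notes: hydroxyethyl amide variant of compound 1

A few compounds are considered here, and "the series" means these few. Any claim that something is new, unique, unknown or untested is made for them only; others in the source may bear on it.

Compound 1 `CNC(=O)c1cc(Oc2ccc3nc(Nc4ccc(Br)cc4)ncc3c2)ccn1`: < 1 10^-6 cm/s
Compound 2 `CNC(=O)c1cc(Oc2ccc3nc(Nc4ccc(-c5cccnc5)cc4)ncc3c2)ccn1`: < 1 10^-6 cm/s

In an ADME assay on Caco-2 cells (Homo sapiens) for permeability, in the apical to basolateral direction (a higher number here means that the compound crosses the layer faster, a lower number that the compound crosses the layer more slowly), compound 1 gives < 1 10^-6 cm/s, which is a limit of the assay and not a number. Compound 2 gives < 1 10^-6 cm/s in this assay, again a limit. The step from compound 1 to compound 2 is a step that the two limits leave unreadable from compound 1 to compound 2; what the two values show is the limit of < 1 10^-6 cm/s in this assay, at which 2 of the 2 values shown sit.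

Compound 3 `O=C(NCCO)c1cc(Oc2ccc3nc(Nc4ccc(Br)cc4)ncc3c2)ccn1` differs from compound 1 by hydroxymethyl in place of hydrogen on a saturated chain carbon bound to an amide-type nitrogen. Within the data shown here, no measured step involves this change, and the single measured step lies between two limits with no readable size. Nothing in the data points away from the limit for compound 3. The expected step is therefore a step that the limit leaves unreadable from compound 1 to compound 3, a value that is expected to remain at the limit rather than a measured shift. For compound 3 the estimate in this assay is 0.5 10^-6 cm/s, expected within 0.1 10^-6 cm/s to 1.5 10^-6 cm/s, most likely reported again as a limit.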

Compound 3, apparent permeability: < 1 10^-6 cm/s
Compound 3: no number, only a limit; the forecaster's own chance of this, stated with the estimate: 85%; the middle value is on the limit's open side.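

Compound 1 and compound 3 are both reported only as limits, so no new step can be read from this pair: the limit of < 1 10^-6 cm/s in this assay, at which 3 of the 3 values shown sit. The compounds shown leave open where the true values lie, and whether methylcarbamoyl and (2-hydroxyethyl)carbamoyl differ at all in this assay.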